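This account rests on a few compounds, and the source may have more. Where it says the series, first, only, none or still open, it means among the compounds named here.

In an assay on CHO cells for displacement of a labelled ligand from adenosine receptor A1 (Homo sapiens), read by scintillation counting, tested at 10 uM (a higher number here means more inhibition at the concentration tested (going by the name of the read-out), a lower number less inhibition), compound 3 `COc1ccccc1-c1sc(N)c(C(=O)c2ccc(Cl)cc2)c1CC(C)(C)C` gives 1%. Compound 1 `CC(C)(C)Cc1c(/C=C/c2ccc(Cl)cc2)sc(N)c1C(=O)c1ccc(Cl)cc1` gives 1% in this assay. Compound 2 `CC(C)(C)Cc1c(-c2ccc(Cl)c(Cl)c2)sc(N)c1C(=O)c1ccc(Cl)cc1` gives 1% in this assay. The steps among these three compounds are no change at the digits printed from compound 1 to compound 2 (within the scatter), no change at the digits printed from compound 1 to compound 3 (within the scatter) and no change at the digits printed from compound 2 to compound 3 (within the scatter), so compound 3 stands level with both of its neighbours and none of the three shows any inhibition of note. Compound 4 `Cc1ccccc1-c1sc(N)c(C(=O)c2ccc(Cl)cc2)c1CC(C)(C)C` differs from compound 3 by methyl in place of methoxy on an aromatic carbon. For the measured compounds named here, no measured step makes this same exchange; the measured steps swap the whole aryl group on that carbon and all stay within the scatter. The step from compound 3 to compound 4 is therefore expected to be a number 1 percentage points higher from compound 3 to compound 4 (within the scatter), nothing beyond the scatter. Compound 4 is estimated at 2%, within 0% to 12%.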

Compound 4, a percentage reported as inhibition, at one concentration (the size of the read-out at that concentration, not a potency): 1%
Compound 4: the middle estimate sits 1 percentage points above what was measured; low and high end bracket the measured number.
By their numbers in this assay, from the lowest: compounds 1, 2, 3 and 4 (each within the scatter of the next).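

In this assay, for the compounds shown here, the exchange of methoxy for methyl on this aromatic carbon, ortho to a large group, shows no change at the digits printed from compound 3 to compound 4 (within the scatter) and so gives a direct reading of this change, which no earlier step offered. The 2-methylphenyl group also stays level with the larger aryl groups, showing no change at the digits printed from compound 2 to compound 4 (within the scatter) and no change at the digits printed from compound 1 to compound 4 (within the scatter) as well. Nothing available explains this flat result.

The compounds shown leave open whether an amine or a carboxylic acid in place of methyl on that aromatic carbon would raise the inhibition at all.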